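A few compounds are considered here, and "the series" means these few. Any claim that something is new, unique, unknown or untested is made for them only; others in the source may bear on it.

Measured in a functional assay on HCT-116 cells (Homo sapiens) for cytotoxicity, read by resazurin assay, with a stated time of 48 h; on this read-out lower numbers stand for an effect already at smaller amounts and higher numbers for an effect only at larger amounts of compound:
compound 1 `COc1ccc(S(=O)(=O)Nc2ccc(-c3nc4cc(NS(=O)(=O)c5ccc(OC)cc5)ccc4o3)cc2)cc1`: 12000 nM
compound 2 `COc1ccc(S(=O)(=O)Nc2ccc3oc(-c4ccc(NC(=O)c5cccc(C)c5[N+](=O)[O-])cc4)nc3c2)cc1`: 4400 nM
compound 3 `O=S(=O)(Nc1ccc(-c2nc3cc(NS(=O)(=O)c4ccc(Br)cc4)ccc3o2)cc1)c1ccc(Br)cc1`: 11000 nM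

Compound 2, at 4400 nM, holds the lowest of the three numbers. Next in line is compound 4 `COc1ccc(S(=O)(=O)Nc2ccc3oc(-c4ccc(NC(=O)c5ccc(Cl)s5)cc4)nc3c2)cc1`, not yet measured in this assay. It carries 5-chlorothiophen-2-yl in place of 3-methyl-2-nitrophenyl on a carbonyl carbon.

Among the measured compounds shown here, only one measured step bears on this change, and only indirectly: a 2.7-fold lower number from compound 1 to compound 2 (0.44 log units; beyond the scatter). This modest step put (3-methyl-2-nitrophenyl)carbonyl in place of (4-methoxyphenyl)sulfonyl on a nitrogen on an aromatic ring. For the measured compounds named here, no measured pair shows an exchange of the group on the carbonyl carbon itself, so the data favour no direction. No step beyond the scatter is expected, although one of similar modest size in either direction remains possible. The estimate amounts to a 1.1-fold higher number from compound 2 to compound 4 (0.06 log units; within the scatter), an expected step within the scatter. Compound 4 is estimated at 5000 nM, with an expected range from 1800 nM to 13000 nM.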

Compound 4, half-maximal effective concentration: 5400 nM
The estimate for compound 4 lay 1.1-fold (0.03 log units) below the measured number; low and high end bracket the measured number.
By their numbers in this assay, from the lowest: compounds 2 and 4 (each within the scatter of the next); then compounds 3 and 1 (each within the scatter of the next).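

In this assay the group on the carbonyl carbon is now exchanged directly, and 5-chlorothiophen-2-yl in place of 3-methyl-2-nitrophenyl gives a 1.2-fold higher number from compound 2 to compound 4 (0.09 log units; within the scatter), so compounds 2 and 4 cannot be told apart and this position takes two quite different aromatic rings with no step beyond the scatter. Among the compounds shown here, the second carbonyl compound also stands apart from the sulfonyl compound, with a 2.2-fold lower number from compound 1 to compound 4 (0.35 log units; beyond the scatter) in the same direction as a 2.7-fold lower number from compound 1 to compound 2 (0.44 log units; beyond the scatter), so that step is not tied to the single group 3-methyl-2-nitrophenyl. Nothing shown gives a reason for either step.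

The compounds shown carry only aromatic rings on this carbonyl carbon, so how a longer alkyl chain, an amine or a carboxylic acid there would read remains open. Also open, going by these compounds, is whether any group on this carbonyl carbon can move the number beyond the scatter from that of compound 2.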